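Naphthyl for Methoxyphenyl on a Weakly Active Analogue

This account rests on a few compounds, and the source may have more. Where it says the series, first, only, none or still open, it means among the compounds named here.

Compound 1 `COc1ccc(C2=NN(C3=NC(=O)/C(=C4\C(=O)Nc5ccc(Br)cc54)S3)C(c3ccc(OC)cc3)C2)cc1` and compound 2 `COc1ccc(C2CC(c3ccc4ccccc4c3)=NN2C2=NC(=O)/C(=C3\C(=O)Nc4ccc(Br)cc43)S2)cc1` share one core, whereas compound 3 `COc1ccc(C2=NN(C3=NC(=O)/C(=C4\C(=O)Nc5ccccc54)S3)C(c3ccc(Cl)cc3)C2)cc1` is built on another; the difference between the two cores is not broken down here. In a functional assay on cells (Cancer cell lines, Homo sapiens) for cytotoxicity, read by sulforhodamine B assay, with a stated time of 48 h (on this read-out higher numbers stand for weaker inhibition of growth and lower numbers for stronger inhibition of growth), compound 1 gives 240 nM and compound 2 gives 110 nM, so that there is a 2.2-fold lower number from compound 1 to compound 2 (0.34 log units; beyond the scatter), the change being (naphthalen-2-yl in place of 4-methoxyphenyl on a carbon with a double bond to nitrogen). In this assay compound 3 gives 100000 nM, the highest of the three numbers. Compound 4 `O=C1N=C(N2N=C(c3ccc4ccccc4c3)CC2c2ccc(Cl)cc2)S/C1=C1/C(=O)Nc2ccccc21` arises from compound 3 by the same kind of change, (naphthalen-2-yl in place of 4-methoxyphenyl on a carbon with a double bond to nitrogen); around that place, the ring atom two ring bonds away bears a 4-chlorophenyl group in compound 3 where it bears a 4-methoxyphenyl group in compound 1. Compound 4 is expected to show a 2.0-fold lower number from compound 3 to compound 4 (0.30 log units; within the scatter), an expectation that rests on a 2.2-fold lower number from compound 1 to compound 2 (0.34 log units; beyond the scatter). Compound 4 is therefore estimated at 50000 nM, most likely between 15000 nM and 150000 nM.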

Compound 4, concentration for 50% growth inhibition: 15400 nM
The estimate for compound 4 lay 3.2-fold (0.51 log units) above the measured number, within the range that was stated.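

In this assay, the change to naphthalen-2-yl gives a 6.5-fold lower number from compound 3 to compound 4 (0.81 log units; beyond the scatter), so the direction of the step seen on the core of compound 1 also holds on the core of compound 3. The size of the step does not carry over unchanged: the same change on two cores in this assay, a 2.2-fold lower number (0.34 log units; beyond the scatter) from compound 1 to compound 2 and a 6.5-fold lower number (0.81 log units; beyond the scatter) from compound 3 to compound 4, 3.0-fold (0.47 log units) apart, beyond the scatter of two such steps These two pairs do not show which feature of the cores sets the size of the step, and they establish no rule for any other core in the series.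

The compounds shown leave open how an unsubstituted phenyl, a pyridin-3-yl group or a butyl chain would compare with naphthalen-2-yl in this place. They also leave open whether an amine or a carboxylic acid on that group would alter the step.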